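The source may hold more compounds than are shown below. What is called first, only, known or untested is meant among the compounds shown, and "the series" means these compounds.

Compound 2, `Cc1ccc(OCC(=O)N(C)Cc2cccs2)cc1`, sits second highest of the three values at hand in an assay on HEK293 cells for agonist activity at transient receptor potential cation channel subfamily M member 8 (Homo sapiens), read by fluorescence and calcium flux, with a stated time of 15 min (on this read-out lower numbers stand for an effect already at smaller amounts and higher numbers for an effect only at larger amounts of compound), where compound 2 gives 400 nM. Its nearest neighbour is compound 3, `CCN(Cc1cccs1)C(=O)COc1ccc(C#N)cc1`, which in this assay gives 1990 nM; the gap between them lies beyond the scatter. Far away stands compound 1, `O=C(COc1ccc2c(c1)CCC2)N(Cc1cccs1)c1ccn[nH]1`, which in this assay gives 0.001 nM and carries a heteroaryl group on its amide-type nitrogen where compound 2 and compound 3 carry a methyl or an ethyl group.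

Compound 4, `Cc1ccc(OCC(=O)N(Cc2cccs2)c2nccn2C)cc1`, has not yet been measured in this assay. It differs from compound 2 in one place: 1-methyl-1H-imidazol-2-yl in place of methyl on an amide-type nitrogen. Among the measured compounds shown here, no single-change pair among the measured compounds shows what such a change does, so the expectation rests on the contrast between compound 1 and the two alkyl-bearing compounds. For compound 4 the step of a 40-fold lower number from compound 2 to compound 4 (1.60 log units; beyond the scatter) is expected to be large and towards smaller numbers. Compound 4 is thus estimated at 10 nM, in a range from 0.3 nM to 300 nM.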

Compound 4, half-maximal effective concentration: 1790 nM
Estimate against measurement, compound 4: 180-fold (2.25 log units) below, outside the stated range (above it).
By their numbers in this assay, from the lowest: compound 1; then compound 2; then compounds 4 and 3 (each within the scatter of the next).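

Among the compounds shown here, on the amide-type nitrogen of the shared core, 1-methyl-1H-imidazol-2-yl in place of methyl gives, in this assay, a 4.5-fold higher number from compound 2 to compound 4 (0.65 log units; beyond the scatter), the first single change that can be read at this position. It shows that, on this core, this heteroaryl group does not lower the number, so a heteroaryl group at this position is not enough on its own to give a very low value. Nothing at hand explains the direction or size of this step.

Compound 1 differs from compound 4 in more than one place. The data at hand do not separate these differences from one another. Also open, on these data alone, is what a pyridine ring, an imidazole without its methyl group, or a propyl chain would do on this nitrogen.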